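Thioester in Place of Ester on a Shared Core

The source may hold more compounds than are shown below. What is called first, only, known or untested is meant among the compounds shown, and "the series" means these compounds.

Measured so far:
- Compound 1, `CC1=C(C(=O)OC(C)(C)C)C(c2ccoc2)NC(=O)N1`: 2%
- Compound 2, `CC1=C(C(=O)OC(C)(C)C)C(c2ccsc2)NC(=O)N1`: 1%
- Compound 3, `CC1=C(C(=O)OCc2ccccc2)C(c2ccsc2)NC(=O)N1`: 25%

All three were tested in an assay on membranes from HeLa cells for displacement of a labelled ligand from adenosine receptor A3 (Homo sapiens), read by scintillation counting, with a stated time of 180 min, tested at 1 uM; a higher number here means more inhibition at the concentration tested (going by the name of the read-out), a lower number less inhibition. Compound 2 gives the lowest number of the three, yet the step of a number 1 percentage points lower from compound 1 to compound 2 (within the scatter) lies within the scatter, so compound 1 and compound 2 cannot be told apart. Compound 3 stands clearly higher: the step of a number 24 percentage points higher from compound 2 to compound 3 (beyond the scatter) is modest but beyond the scatter.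

Compound 4, `CCSC(=O)C1=C(C)NC(=O)NC1c1ccsc1`, has not been measured. It differs from compound 2 at the carbonyl carbon: ethylsulfanyl in place of tert-butoxy on a carbonyl carbon. Among the measured compounds shown here, the only measured step at that carbon is the one from tert-butyl to benzyl, which gave a modest rise; no measured step shows an ethylsulfanyl group, so it bears only loosely on the change here. A small rise at most is therefore expected, and the step from compound 2 to compound 4 is estimated as a number 7 percentage points higher from compound 2 to compound 4 (within the scatter). For compound 4 the estimate is 8%, ranging from 0% to 25%.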

Compound 4, a percentage reported as inhibition, at one concentration (the size of the read-out at that concentration, not a potency): 2%
Compound 4: the middle estimate sits 6 percentage points above what was measured, and the stated range covers the measured number.
By their numbers in this assay, from the lowest: compounds 2, 1 and 4 (each within the scatter of the next); then compound 3.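

In this assay the exchange of tert-butoxy for ethylsulfanyl on the carbonyl carbon gives a number 1 percentage points higher from compound 2 to compound 4 (within the scatter), so the thioester and the ester cannot be told apart here. Among the compounds shown here, this position does not respond to every exchange, as the benzyl step, a number 24 percentage points higher from compound 2 to compound 3 (beyond the scatter), finds no counterpart with ethylsulfanyl. Nothing measured here explains this result.

The change swaps the linking oxygen for sulfur and also alters the chain, so the compounds shown cannot separate those two changes; an ethoxy group on the same carbonyl carbon would pair the ethyl chain with oxygen. A benzylsulfanyl group there would likewise show whether the benzyl group still gives a higher number when attached through sulfur.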